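The source may report more compounds than this note shows. Statements on the series, on what has been measured and on what is new or still open speak of the compounds shown alone.

Measured so far in a functional assay on HCT-116 cells (Homo sapiens) for cytotoxicity, read by MTT assay, with a stated time of 72 h; a higher number here means a weaker inhibitor, a lower number a stronger inhibitor

Compound 1 `[O-][S+](CCCCN=C=S)CCc1ccccc1` gives 8020 nM
Compound 2 `[O-][S+](CCCN=C=S)Cc1ccccc1` gives 15600 nM

Among the compounds with values here, compound 1 at 8020 nM and compound 2 at 15600 nM lie within the usual scatter of each other, so compound 2 stands level with the only other number available. Compound 3 `[O-][S+](CCCCCCN=C=S)Cc1ccccc1` has not yet been measured. Going from compound 2 to compound 3 brings a group of 6 heavy atoms (4 carbon, 1 nitrogen, 1 sulfur; no ring) in place of a group of 3 heavy atoms (1 carbon, 1 nitrogen, 1 sulfur; no ring), on a saturated chain carbon, three bonds along the chain from a sulfur on a saturated chain carbon, three bonds along the chain from a sulfur. Within the data shown here, no two measured compounds differ in one place only, so no measured step can guide this change, and only a modest move is expected. The step of a 2.0-fold lower number from compound 2 to compound 3 (0.29 log units; within the scatter) is expected to run toward a lower number in this assay and to stay about the size of the scatter. For compound 3 the estimated value is 8000 nM with an expected range from 3500 nM to 16000 nM.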

Compound 3, half-maximal inhibitory concentration: 11600 nM
Estimate against measurement, compound 3: 1.5-fold (0.16 log units) below, and the stated range covers the measured number.
By their numbers in this assay, from the lowest: compounds 1, 3 and 2 (each within the scatter of the next).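

Within the data shown here, this is the first pair here that differs in one place only. On a saturated chain carbon, three bonds along the chain from a sulfur, a group of 6 heavy atoms stands in place of a group of 3 heavy atoms, and this assay records a 1.3-fold lower number from compound 2 to compound 3 (0.13 log units; within the scatter), so this exchange, which carries 4 carbon in place of 1, does not separate the two compounds in this test. Nothing measured on these compounds explains that result.

One exchange at one position cannot show whether a longer chain at this place would also stay level with compound 2. It also leaves open whether an amine or a carboxylic acid in place of the group on this chain would give a number beyond the scatter.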